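One Aromatic Ring Swapped in a Weakly Active Series

The source may hold more compounds than are shown below. What is called first, only, known or untested is meant among the compounds shown, and "the series" means these compounds.

Three compounds share one core and were tested in a functional assay on DU-145 cells (Homo sapiens) for cytotoxicity, read by sulforhodamine B assay, with a stated time of 48 h; on this read-out lower numbers stand for stronger inhibition of growth and higher numbers for weaker inhibition of growth:

Compound 1 `N#Cc1ccc(Nc2nc(Oc3ccnc4ccccc34)nc(N3CCN(c4ccccc4Cl)CC3)n2)cc1C(F)(F)F` gives 92600 nM.
Compound 2 `N#Cc1ccc(Nc2nc(Oc3ccnc4ccccc34)nc(N3CCN(c4ccc(F)cc4)CC3)n2)cc1C(F)(F)F` gives > 100000 nM, which is a limit of the measurement and not a number.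
Compound 3 `N#Cc1ccc(Nc2nc(Oc3ccnc4ccccc34)nc(N3CCN(c4ccccn4)CC3)n2)cc1C(F)(F)F` gives 85900 nM.

Compound 3 holds the lowest of the two actual numbers, but its nearest neighbour is close: a 1.1-fold lower number from compound 1 to compound 3 (0.03 log units; within the scatter). The other two steps are equally small: an at least 1.0-fold higher number from compound 1 to compound 2 (0.03 log units; that floor lies within the scatter) and an at least 1.1-fold lower number from compound 2 to compound 3 (0.06 log units; that floor lies within the scatter). All three compounds differ only in the aromatic ring attached to the amine nitrogen of the ring, and none of these exchanges moved the growth-inhibition read-out beyond the usual scatter; one of them ends at the limit of > 100000 nM in this assay, at which 1 of the 3 values shown sits.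

Compound 4 `N#Cc1ccc(Nc2nc(Oc3ccnc4ccccc34)nc(N3CCN(c4ncccn4)CC3)n2)cc1C(F)(F)F` has not yet been measured. It differs from compound 3 by pyrimidin-2-yl in place of pyridin-2-yl on an amine nitrogen in a ring. Since every earlier swap of this aromatic ring, whether with or without a ring nitrogen, left the read-out essentially unchanged, the expected step is none beyond the scatter: a 1.0-fold higher number from compound 3 to compound 4 (0.02 log units; within the scatter). Compound 4 is therefore estimated at 90000 nM in this assay, with a plausible range from 40000 nM to 200000 nM, and a real chance that only a limit is reported.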

Compound 4, concentration for 50% growth inhibition: 85200 nM
The estimate for compound 4 lay 1.1-fold (0.02 log units) above the measured number; measured number inside the range.
By their numbers in this assay, from the lowest: compounds 4, 3 and 1 (each within the scatter of the next). At a limit, above all of these: compound 2.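

Putting a second ring nitrogen into this position, with pyrimidin-2-yl in place of pyridin-2-yl, raises the hydrogen-bond acceptor count of the group yet leaves the growth-inhibition read-out in this assay unchanged: a 1.0-fold lower number from compound 3 to compound 4 (0.00 log units; within the scatter). Compound 4 also stays within the scatter of the 2-chlorophenyl analogue, a 1.1-fold lower number from compound 1 to compound 4 (0.04 log units; within the scatter), so the earlier result for a ring with one nitrogen now extends to a ring with two, while the comparison with the 4-fluorophenyl analogue gives only a floor, an at least 1.1-fold lower number from compound 2 to compound 4 (0.06 log units; that floor lies within the scatter). Compound 2 therefore cannot be placed exactly in this flat picture, as its value is a limit and not a number: the limit of > 100000 nM in this assay, at which 1 of the 4 values shown sits.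

The compounds shown leave open whether a group of another kind on this amine nitrogen, such as a benzyl group or a plain methyl group, would move the read-out beyond the scatter. They also leave open whether these ring swaps would stay just as silent on a core carrying an amine in place of the nitrile.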